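The source may report more compounds than this note shows. Statements on the series, on what has been measured and on what is new or still open speak of the compounds shown alone.

Compound 1 `O=C(/C=C\Nc1ccc(O)cc1)c1cn(-c2ccccc2)nc1-c1ccccc1` gives 3210 nM in a functional assay on A549 cells (Homo sapiens) for antiproliferative activity, read by MTT assay, with a stated time of 48 h; on this read-out lower numbers stand for stronger inhibition and higher numbers for weaker inhibition.
Compound 2 `O=C(/C=C\Nc1ccc(O)cc1)c1cn(-c2ccccc2)nc1-c1ccc(F)cc1` gives 1500 nM in this assay.
Compound 3 `O=C(/C=C\Nc1ccc(Cl)cc1)c1cn(-c2ccccc2)nc1-c1ccc(Cl)cc1` gives 3670 nM in this assay.

Compound 3 carries the highest of the three numbers in this assay. Its gap to compound 1 lies within the scatter, while compound 2 sits beyond the scatter below it, so compound 3 can be called no weaker than compound 1, only weaker than compound 2.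

Compound 4 `O=C(/C=C\Nc1ccc(O)cc1)c1cn(-c2ccccc2)nc1-c1ccc(Cl)cc1` differs from compound 3 in one place: hydroxy in place of chloro on an aromatic carbon. Going by the values given here, no measured step touches this position directly. Among the compounds with values here, the only step on record, a 2.1-fold lower number from compound 1 to compound 2 (0.33 log units; beyond the scatter), concerns the other aromatic ring and shows a modest lowering of the number. Compounds 1 and 3 differ in two places at once, and their values lie within the scatter of each other, so they reveal little about the hydroxy for chloro exchange on its own. Compound 4 shares its hydroxy-bearing ring with compound 2, which gives the lowest number of the set.

On this thin basis, the step of a 2.0-fold lower number from compound 3 to compound 4 (0.31 log units; beyond the scatter) is expected to be a modest lowering of the number, not beyond what compound 2 already shows. Compound 4 is estimated at 1800 nM in this assay, with a range from 800 nM to 4000 nM.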

Compound 4, half-maximal inhibitory concentration: 1910 nM
Beside the measured number, compound 4's estimate is 1.1-fold (0.03 log units) below it; low and high end bracket the measured number.
By their numbers in this assay, from the lowest: compounds 2, 4, 1 and 3 (each within the scatter of the next, the first and the last beyond it).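

In this assay, going by these compounds alone, the step of a 1.9-fold lower number from compound 3 to compound 4 (0.28 log units; within the scatter) is the first direct reading of hydroxy in place of chloro at this position, on the ring of the (4-chlorophenyl)amino group, and it shows that this exchange alone does not separate the two compounds. On the other aromatic ring, chloro cannot be told apart from fluoro, with a 1.3-fold higher number from compound 2 to compound 4 (0.10 log units; within the scatter), or from hydrogen, with a 1.7-fold lower number from compound 1 to compound 4 (0.23 log units; within the scatter), even though fluoro and hydrogen themselves are separated by a 2.1-fold lower number from compound 1 to compound 2 (0.33 log units; beyond the scatter), so chloro at that place sits within the scatter of both neighbours. Nothing on hand explains these readings, and no independent measurement bears on them.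

Within the data shown here, it remains open whether a methoxy group, an amine or a carboxylic acid at the position now held by hydroxy would move the number beyond the scatter, since hydroxy and chloro are the only two groups seen there with the rest of the molecule held constant. Going by these compounds, it is equally open whether bromo or trifluoromethyl on the other aromatic ring would extend the small spread seen among hydrogen, fluoro and chloro.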